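Swapping the benzyl ring: from methyl to two chlorines

This account rests on a few compounds, and the source may have more. Where it says the series, first, only, none or still open, it means among the compounds named here.

Measured so far:
- compound 1, `Cc1ccc(CS/C(=C/c2ccc(Cl)c([N+](=O)[O-])c2)C(=O)c2ccc(C(=O)O)cc2)cc1`: 1000 nM
- compound 2, `Cc1ccc(CS/C(=C/c2ccc(F)c([N+](=O)[O-])c2)C(=O)c2ccc(C(=O)O)cc2)cc1`: 1000 nM

Among the measured compounds shown here, in a functional assay on DU-145 cells (Homo sapiens) for inhibition, read by trypan blue exclusion, with a stated time of 96 h (on this read-out lower numbers stand for stronger inhibition of growth and higher numbers for weaker inhibition of growth), compound 1 gives 1000 nM and stands level with compound 2, whose value is 1000 nM; the only measured step, no change at the digits printed from compound 1 to compound 2 (within the scatter), lies within the scatter. Compound 3, `O=C(O)c1ccc(C(=O)/C(=C\c2ccc(Cl)c([N+](=O)[O-])c2)SCc2ccc(Cl)cc2Cl)cc1`, has not been measured. Its difference from compound 1 is 2,4-dichlorophenyl in place of 4-methylphenyl on a saturated chain carbon bound to a sulfur. For the measured compounds named here, no measured step touches this part of the structure, so nothing here points toward a shift in either direction beyond the scatter. The value of compound 3 is therefore expected close to that of compound 1, with the step of no change at the digits printed from compound 1 to compound 3 (within the scatter); the estimate for compound 3 is 1000 nM, with a range from 300 nM to 3000 nM.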

Compound 3, concentration for 50% growth inhibition: 1000 nM
Estimate against measurement, compound 3: no gap at the digits printed, within the range that was stated.
By their numbers in this assay, from the lowest: compounds 1, 2 and 3 (each within the scatter of the next).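

Among the compounds shown here, replacing 4-methylphenyl with 2,4-dichlorophenyl on the saturated chain carbon bound to a sulfur gives the first reading at this position: in this assay, the step is no change at the digits printed from compound 1 to compound 3 (within the scatter), with the rest of the structure unchanged. This position therefore accepts two chlorines in place of one methyl without a shift beyond the scatter. No supporting data bear on why the value holds. Still open, going by these compounds, is how an amine or a carboxylic acid on this ring would read. A longer chain between the sulfur and the ring is also untested among these compounds.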